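The source may report more compounds than this note shows. Statements on the series, on what has been measured and on what is new or still open speak of the compounds shown alone.

Among the measured compounds shown here, the measured compounds so far are three: compound 1 `N#CC1CN1C(=O)Nc1ccc(Cl)c(Cl)c1`, which in a functional assay on L1210 cells (Mus musculus) for inhibition, read by MTT assay (on this read-out higher numbers stand for weaker inhibition and lower numbers for stronger inhibition), gives 7200 nM; compound 2 `CCCCNC(=O)N1CC1C#N`, which in this assay gives 12000 nM; and compound 3 `N#CC1CN1C(=O)Nc1ccc(F)cc1`, which in this assay gives 5900 nM.

Compound 3 has the lowest of the three numbers. Its value and that of compound 1 lie within the scatter of each other, so nothing separates the two; the value of compound 2 stands beyond the scatter above that of compound 3. For the measured compounds named here, no single-point step between measured compounds is available to guide the next change.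

The change leading to compound 4 `CCOC(=O)c1ccc(NC(=O)N2CC2C#N)cc1` is ethoxycarbonyl in place of fluoro on an aromatic carbon. Both groups sit on the same aromatic carbon of the shared core, and the aryl urea part of compound 3 is kept.

With only the values of compounds 1 and 3 as a reference for aryl ureas, no step beyond the scatter is expected in this assay from compound 3 to compound 4. The estimated step of a 1.1-fold higher number from compound 3 to compound 4 (0.04 log units; within the scatter) is close to none. Compound 4 is therefore estimated at 6500 nM, with a range from 2200 nM to 20000 nM.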

Compound 4, half-maximal inhibitory concentration: 9700 nM
Compound 4: middle estimate off by 1.5-fold (0.17 log units), on the low side; the range from low to high includes it.
By their numbers in this assay, from the lowest: compounds 3, 1, 4 and 2 (each within the scatter of the next, the first and the last beyond it).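

In this assay, putting ethoxycarbonyl in place of fluoro on an aromatic carbon gives a 1.6-fold higher number from compound 3 to compound 4 (0.22 log units; within the scatter), the first step available at this position. The position therefore takes ethoxycarbonyl, with 5 heavy atoms and 2 hydrogen-bond acceptors, in place of fluoro, with 1 heavy atom and none, without a difference that can be read beyond the scatter. Nothing in the available data accounts for this result, and no cause can be assigned to it.

As far as these compounds go, it remains open whether an amine or a carboxylic acid on this aromatic carbon would give a step beyond the scatter. From the compounds shown here alone, it is also open whether a longer chain on the ester would keep the number within the scatter of compound 4.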